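Tail amine swap: from compound 2 to compound 3

The source may report more compounds than this note shows. Statements on the series, on what has been measured and on what is new or still open speak of the compounds shown alone.

Of the compounds shown here, two have numbers so far. Compound 1 `COc1cc2c(Oc3ccc(NC(=O)c4cc(-c5ccc(F)cc5)ccn4)cc3F)ccnc2cc1OCCCN1CCN(C)CC1` gives 430 nM in a functional assay on NCI-H460 cells (Homo sapiens) for cytotoxicity, read by MTT assay, with a stated time of 72 h; on this read-out higher numbers stand for weaker inhibition and lower numbers for stronger inhibition. Going by the values given here, compound 2 `COc1cc2c(Oc3ccc(NC(=O)c4cc(-c5ccc(C(F)(F)F)cc5)ccn4)cc3F)ccnc2cc1OCCCN1CCN(C)CC1` gives 160 nM in this assay, and the single measured step, a 2.7-fold lower number from compound 1 to compound 2 (0.43 log units; beyond the scatter), lies at the aryl end of the molecule. Among the compounds with values here, on the two numbers available, compound 2 stands lowest, its only neighbour being compound 1 at a gap beyond the scatter.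

Compound 3 `COc1cc2c(Oc3ccc(NC(=O)c4cc(-c5ccc(C(F)(F)F)cc5)ccn4)cc3F)ccnc2cc1OCCCN1CCCC1` keeps the whole of compound 2 except the tail: pyrrolidin-1-yl in place of 4-methylpiperazin-1-yl on a saturated chain carbon, three bonds along the chain from an oxygen on an aromatic ring. Within the data shown here, no measured step touches this tail; the one step available concerns a substituent on the distal aromatic ring and says nothing about the amine at the chain end. Among the measured compounds shown here, with no step bearing on the change, the expectation for compound 3 in this assay is a number near that of compound 2, and the expected step of a 1.3-fold higher number from compound 2 to compound 3 (0.10 log units; within the scatter) is taken as one within the scatter in either direction. The estimate for compound 3 in this assay is therefore 200 nM, with a range from 70 nM to 600 nM.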

Compound 3, half-maximal inhibitory concentration: 250 nM
Compound 3: the middle estimate sits 1.3-fold (0.10 log units) below what was measured, within the range that was stated.
By their numbers in this assay, from the lowest: compounds 2, 3 and 1 (each within the scatter of the next, the first and the last beyond it).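

The tail position gives its first reading in this assay: pyrrolidin-1-yl in place of 4-methylpiperazin-1-yl, on a saturated chain carbon three bonds along the chain from an oxygen on an aromatic ring, gives a 1.6-fold higher number from compound 2 to compound 3 (0.19 log units; within the scatter). Going by these compounds alone, on this pair, the five-membered ring with 1 hetero atom and the six-membered ring with 2 hetero atoms cannot be told apart, even though the entering group has 5 heavy atoms against 7 for the one it replaces; by contrast, the only earlier step, the trifluoromethyl-for-fluoro change of a 2.7-fold lower number from compound 1 to compound 2 (0.43 log units; beyond the scatter), lies beyond the scatter. No measurement is available that would bear on this result.

Within the data shown here, only one pair reads the tail, so it remains open whether the same swap gives a step of similar size alongside fluoro instead of trifluoromethyl. Also open, as far as these compounds go, is how the read-out responds to a morpholin-4-yl or dimethylamino group at the chain end, or to a shorter 2-(pyrrolidin-1-yl)ethyl chain or a longer chain carrying the same amine.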